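Moving the amino group around the pendant phenyl ring

The compounds below may be only part of what the source reports. "The series", "measured", "known", "first", "only" and "open" are said of these compounds alone.

Three compounds share one core and differ only in the aromatic ring attached to it. Compound 1 is `CCCS(=O)(=O)Nc1ccc(F)c(C(=O)c2n[nH]c3ncc(-c4cccc(OC)c4)cc23)c1F`, compound 2 is `CCCS(=O)(=O)Nc1ccc(F)c(C(=O)c2n[nH]c3ncc(-c4ccccc4O)cc23)c1F` and compound 3 is `CCCS(=O)(=O)Nc1ccc(F)c(C(=O)c2n[nH]c3ncc(-c4cccc(N)c4)cc23)c1F`. In an assay for binding affinity to dual specificity mitogen-activated protein kinase kinase 4 (Homo sapiens), read by KINOMEscan, tested at 100 nM (a higher number here means a weaker effect of the compound at the concentration tested, a lower number a stronger effect), compound 1 gives 6.3%, compound 2 gives 9% and compound 3 gives 1.6%. None of these readings is separated from another by more than the usual scatter: in this assay the step is a number 2.7 percentage points higher from compound 1 to compound 2 (within the scatter), a number 4.7 percentage points lower from compound 1 to compound 3 (within the scatter) and a number 7.4 percentage points lower from compound 2 to compound 3 (within the scatter). Among the compounds with values here, compound 3 therefore sits with the others, with no step to either of them beyond the scatter.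

Compound 4 is `CCCS(=O)(=O)Nc1ccc(F)c(C(=O)c2n[nH]c3ncc(-c4ccc(N)cc4)cc23)c1F`. It differs from compound 3 by 4-aminophenyl in place of 3-aminophenyl on an aromatic carbon. Every measured step between these pendant rings, including the change from a methoxy to an amino group, stayed within the scatter, so the change to compound 4 is expected to give a number 2.4 percentage points higher from compound 3 to compound 4 (within the scatter), a step within the scatter. The estimate for compound 4 in this assay is 4%, expected to fall between 0.8% and 15%.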

Compound 4, a percentage reported as activity, at one concentration (the size of the read-out at that concentration, not a potency): 0.1%
Beside the measured number, compound 4's estimate is 3.9 percentage points above it, outside the stated range (below it).
By their numbers in this assay, from the lowest: compounds 4, 3, 1 and 2 (each within the scatter of the next).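

Swapping the 3-aminophenyl ring for the 4-aminophenyl ring gives a number 1.5 percentage points lower from compound 3 to compound 4 (within the scatter) in this assay, so moving the amino group to this other place on the pendant ring produces no step that can be told from the scatter. The comparisons with the other two rings read the same way, with a number 8.9 percentage points lower from compound 2 to compound 4 (within the scatter) and a number 6.2 percentage points lower from compound 1 to compound 4 (within the scatter), so all four rings on this position of the shared core remain a single group of readings. Nothing measured here bears on why these readings fall as they do.

All four readings come from one concentration, so they cannot show whether the compounds would separate in a full potency measurement. A carboxylic acid or a dimethylamino group on the pendant ring, in place of the amino group, might read apart from these four, and the compounds shown leave that open.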